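This account rests on a few compounds, and the source may have more. Where it says the series, first, only, none or still open, it means among the compounds named here.

Compounds measured in a functional assay on the whole organism (strain Wistar) for inhibition, with Rattus norvegicus as the target, read by paw edema, with stated times of 30 min and 5 h, at a dose of 0.05 mmol/kg by the oral route; a lower number here means less inhibition, a higher number more inhibition at the dose given (going by the name of the read-out):

Compound 1, `Cc1ccc(C2=NN(c3ccc(S(C)(=O)=O)cc3)C(=O)CC2)cc1`: 60.5%
Compound 2, `CS(=O)(=O)c1ccc(N2N=C(c3ccc(Cl)cc3)CCC2=O)cc1`: 36.8%

Compound 1 stands highest of the two numbers; the nearest is compound 2, and the step of a number 23.7 percentage points lower from compound 1 to compound 2 (beyond the scatter) is a modest one that lies beyond the scatter. That step is the only one measured so far, and it exchanges one group for another on the same aromatic carbon that is changed next.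

Compound 3, `CC(C)(C)c1ccc(C2=NN(c3ccc(S(C)(=O)=O)cc3)C(=O)CC2)cc1`, has not yet been measured in this assay. It differs from compound 1 as follows: tert-butyl in place of methyl on an aromatic carbon

The step from compound 1 to compound 2 bears only loosely on this change, since it introduces chloro rather than tert-butyl; still, it shows that a swap at this aromatic carbon can lower the inhibition by a modest, beyond-scatter amount. Going by the values given here, with no step that directly matches tert-butyl, compound 3 is expected to fall somewhat below compound 1, the step of a number 10.5 percentage points lower from compound 1 to compound 3 (beyond the scatter) being estimated as small to modest. The estimate for compound 3 is therefore 50%, with a range from 25% to 72%.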

Compound 3, a percentage reported as inhibition, in the whole organism at one dose (the size of the read-out at that dose, not a potency): 68.4%
For compound 3 the middle estimate is 18.4 percentage points below the measured one; low and high end bracket the measured number.
By their numbers in this assay, from the lowest: compound 2; then compounds 1 and 3 (each within the scatter of the next).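

In this assay, tert-butyl in place of methyl gives a number 7.9 percentage points higher from compound 1 to compound 3 (within the scatter), so on this aromatic carbon the larger group, with 4 heavy atoms in place of 1, leaves the read-out indistinguishable from that of the smaller one. The low number of compound 2 therefore now stands apart from both alkyl-bearing compounds: beside a number 23.7 percentage points lower from compound 1 to compound 2 (beyond the scatter), there is also a number 31.6 percentage points higher from compound 2 to compound 3 (beyond the scatter), so among these three groups it is chloro alone that separates from the others. Nothing available here accounts for why chloro differs from methyl and tert-butyl at this place.

As far as these compounds go, it remains open whether the lower number belongs to chloro specifically or would also appear with fluoro, bromo or methoxy, and whether an amine or a carboxylic acid on this carbon would stay with the alkyl groups or fall with chloro. From the compounds shown here alone, since the read-out gives the size of the inhibition at a single dose and not a potency, it also remains open whether compound 1 and compound 3 would still match at other doses.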